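The source may report more compounds than this note shows. Statements on the series, on what has been measured and on what is new or still open speak of the compounds shown alone.

In a functional assay on CHO cells for agonist activity at Alpha-1B adrenergic receptor (Homo sapiens), read by FLIPR and calcium flux (a higher number here means that more compound is needed for the effect, a lower number that less compound is needed), compound 3 `c1ccc(-c2cccc3c2CCC3c2ncc[nH]2)nc1` gives > 10000 nM, which is a limit of the assay and not a number. Compound 1 `CS(=O)(=O)Nc1cccc2c1CCC2c1ncc[nH]1` gives > 10000 nM, likewise a limit. Compound 2 `CCS(=O)(=O)Nc1cccc2c1CCC2c1ncc[nH]1` gives > 10000 nM, again a limit. All three values sit at the limit of > 10000 nM in this assay, at which 3 of the 3 values shown sit, so compound 3 stands nowhere on a readable scale. The change to compound 4 `CNC(=O)c1cccc2c1CCC2c1ncc[nH]1` is methylcarbamoyl in place of pyridin-2-yl on an aromatic carbon. The steps that touch this position, a step that the two limits leave unreadable from compound 1 to compound 3 and a step that the two limits leave unreadable from compound 2 to compound 3, together with a step that the two limits leave unreadable from compound 1 to compound 2, are all unreadable, so none of them sets a size or a direction. The step that the limit leaves unreadable from compound 3 to compound 4 is therefore expected to be small or none beyond the scatter. Compound 4 is estimated at 15000 nM, between 3000 nM and 60000 nM, most likely reported only as a limit.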

Compound 4, half-maximal effective concentration: > 10000 nM
Compound 4: only a limit was reported; the forecaster's own chance of this, stated with the estimate: 80%; the middle value lies beyond the limit too.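

Compound 4 also gives only a limit, so no step from compound 1, compound 2 or compound 3 to compound 4 can be read in this assay: the limit of > 10000 nM in this assay, at which 4 of the 4 values shown sit.

The compounds shown leave open whether any group at this place on the shared core gives a readable value.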